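From methoxy to trifluoromethoxy on a shared core

A few compounds are considered here, and "the series" means these few. Any claim that something is new, unique, unknown or untested is made for them only; others in the source may bear on it.

In a functional assay on HL-60 cells (Homo sapiens) for cytotoxicity, read by WST assay, with a stated time of 48 h (a higher number here means that more compound is needed for the effect, a lower number that less compound is needed), compound 1 (`O=C1OC[C@H](Cc2ccccc2)[C@H]1Cc1ccc(O)cc1`) gives 88000 nM, and compound 2 (`COc1ccc(C[C@H]2C(=O)OC[C@@H]2Cc2ccccc2)cc1`) gives 67000 nM. Among the measured compounds shown here, these are the only two numbers available, and they lie within the scatter of each other, so compound 2 holds no distinct place beside compound 1.

Compound 3 (`O=C1OC[C@H](Cc2ccccc2)[C@H]1Cc1ccc(OC(F)(F)F)cc1`) has not yet been measured. It departs from compound 2 at the oxygen on the aromatic ring: trifluoromethyl in place of methyl on an oxygen on an aromatic ring. In words, this is trifluoromethyl in place of methyl on an oxygen on an aromatic ring.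

For the measured compounds named here, only one measured step bears on this change, since it falls at the same oxygen: a 1.3-fold lower number from compound 1 to compound 2 (0.12 log units; within the scatter). That step replaced hydrogen with methyl and stayed within the scatter, so no clear shift in either direction is expected in this assay. Going by the values given here, no measured compound carries trifluoromethyl, however, so the range is kept wide. The expected change is a 1.1-fold lower number from compound 2 to compound 3 (0.05 log units; within the scatter), which is no step beyond the scatter. Compound 3 is estimated at 60000 nM, with an expected range from 25000 nM to 120000 nM.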

Compound 3, half-maximal effective concentration: 27000 nM
The estimate for compound 3 lay 2.2-fold (0.35 log units) above the measured number; the range from low to high includes it.
By their numbers in this assay, from the lowest: compound 3; then compounds 2 and 1 (each within the scatter of the next).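

In this assay, this oxygen on an aromatic ring now proves to be a place where a single change can move the number beyond the scatter: trifluoromethyl in place of methyl gives a 2.5-fold lower number from compound 2 to compound 3 (0.39 log units; beyond the scatter). The earlier change at the same oxygen, methyl in place of hydrogen, had given only a 1.3-fold lower number from compound 1 to compound 2 (0.12 log units; within the scatter), which left open whether substitution there mattered at all in this assay, while trifluoromethyl in place of hydrogen gives a 3.3-fold lower number from compound 1 to compound 3 (0.51 log units; beyond the scatter), so compound 3 has the lowest number of the three and is set apart from both of the others. These are modest steps, and nothing available explains why trifluoromethyl differs from methyl here.

The compounds shown leave open whether the fall in the number is particular to trifluoromethyl or would also appear with another group on the same oxygen, such as ethyl, difluoromethyl or a longer chain. They also leave open whether the same replacement would give a step of similar size on a different core, or in cells other than those of this assay.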